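This account rests on a few compounds, and the source may have more. Where it says the series, first, only, none or still open, it means among the compounds named here.

Compound 1 `Cc1ccc(C(C)C)c(OC(=O)c2cn(-c3ccccc3)nc2-c2cccnc2)c1`: 84200 nM
Compound 2 `CCc1ccc(OC(=O)c2cn(-c3ccccc3)nc2-c2ccncc2)cc1`: "nd(insoluble)" (no result reported)
Compound 3 `O=C(Oc1ccc(-c2ccccc2)cc1)c1cn(-c2ccccc2)nc1-c1ccncc1`: "nd(insoluble)" (no result reported)

In a functional assay on MCF7 cells (Homo sapiens) for cytotoxicity, read by MTT assay, with a stated time of 48 h (on this read-out higher numbers stand for weaker inhibition and lower numbers for stronger inhibition), compound 1 gives 84200 nM. Compound 2 has no number there: in this assay compound 2 gives "nd(insoluble)" (no result reported), and compound 3 likewise gives "nd(insoluble)" (no result reported). Compound 2 therefore cannot be placed against any other compound on the numbers shown, and compound 1 alone supplies a measured value. Compound 4 `O=C(O)c1cn(-c2ccccc2)nc1-c1ccncc1` is not yet measured. It differs from compound 2 by hydrogen in place of 4-ethylphenyl on an oxygen next to a carbonyl group. For the measured compounds named here, with no measured pair to lean on, the size of this step in this assay cannot be read from the data; weak inhibition like that of compound 1 84200 nM seems the likeliest outcome. Compound 4 is expected to come in near 120000 nM, within 30000 nM to 500000 nM.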

Compound 4, half-maximal inhibitory concentration: > 100000 nM
Compound 4: a limit, no number; the forecaster's own chance of this, stated with the estimate: 50%; the middle value lies beyond the limit too.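

No step can be read between compound 2 and compound 4: compound 2 has no number. Compound 4 gives > 100000 nM, which is a limit. The compounds shown leave open what replacing 4-ethylphenoxy with hydroxy does to cytotoxicity.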